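The compounds below may be only part of what the source reports. "The series", "measured", "known", "first", "only" and "open" are said of these compounds alone.

Measured compounds:
Compound 1, `O=C(N/N=C/c1cc(I)cc(I)c1O)c1ccc([N+](=O)[O-])cc1`, gives 24700 nM in a functional assay on HepG2 cells (Homo sapiens) for cytotoxicity, with a stated time of 24 h; a lower number here means a stronger inhibitor, a higher number a weaker inhibitor.
Compound 2, `O=C(N/N=C/c1cc(I)c(O)c(I)c1)c1ccccc1`, gives 191000 nM in this assay.

Of the two compounds with numbers in this assay, compound 2 has the higher one; the nearest is compound 1, whose number is lower by a margin that lies beyond the usual scatter of repeated measurements. Compound 1 and compound 2 differ in more than one place, so nothing can be said about which of those differences carries that gap. The next compound, compound 3, `O=C(N/N=C/c1cc(I)c(O)c(I)c1)c1ccc(F)cc1`, differs from compound 2 in a single place: fluoro in place of hydrogen on an aromatic carbon. No pair of measured compounds shows this change, so no step for it can be read from the numbers shown. With only that to go on, the change from compound 2 to compound 3 is expected to bring at most a small step in this assay, and none that clearly goes beyond the scatter in either direction. Compound 3 is therefore expected to give about 150000 nM in this assay, with a range from 50000 nM to 400000 nM. The step this estimate means is expected to be a 1.3-fold lower number from compound 2 to compound 3 (0.10 log units; within the scatter).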

Compound 3, half-maximal inhibitory concentration: 117000 nM
The estimate for compound 3 lay 1.3-fold (0.11 log units) above the measured number, within the range that was stated.
By their numbers in this assay, from the lowest: compound 1; then compounds 3 and 2 (each within the scatter of the next).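

Going by these compounds alone, replacing hydrogen with fluoro, the change from phenyl to 4-fluorophenyl, gives in this assay a 1.6-fold lower number from compound 2 to compound 3 (0.21 log units; within the scatter), and this is the only step so far that can be tied to a single place. It shows that, on this aromatic carbon para to a large group, adding this one heavy atom does not shift the number beyond the usual scatter, which no earlier comparison could show. Nothing measured here bears on why the step is this size.

From the compounds shown here alone, whether an amine, a carboxylic acid, a methoxy group or a longer chain on this same aromatic carbon would give a step beyond the scatter remains open, since a single small replacement with a step within the scatter says little about larger groups. Also open, going by these compounds, is whether fluoro would give a similar step on the core of compound 1, and which of the several differences between compound 1 and the other two compounds carries the gap between their numbers.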